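The compounds below may be only part of what the source reports. "The series", "measured", "known", "first", "only" and "open" are said of these compounds alone.

Compound 2 `COc1ccc(/C=C2\CCC/C(=C\c3cccc(Cl)c3)C2=O)cc1OC` and compound 1 `COc1cccc(/C=C2\CCC/C(=C\c3cccc(Br)c3)C2=O)c1OC` were both tested in a functional assay on MCF7 cells (Homo sapiens) for cytotoxicity, read by MTT assay, with a stated time of 72 h; on this read-out higher numbers stand for weaker inhibition and lower numbers for stronger inhibition. Compound 2 gives 6000 nM in this assay, and compound 1 gives 11700 nM, so compound 2 has the lower of the two numbers, though the gap to compound 1 is within the scatter, and no order between them can be claimed. Compound 3 `COc1ccc(/C=C2\CCC/C(=C\c3ccc(Cl)cc3Cl)C2=O)cc1OC` differs from compound 2 in one place: 2,4-dichlorophenyl in place of 3-chlorophenyl on a double-bonded chain carbon bound to a double-bonded ring carbon. For the measured compounds named here, no measured pair shows a step of this kind, so compound 3 is expected to give a number near that of compound 2, with a 1.1-fold lower number from compound 2 to compound 3 (0.04 log units; within the scatter) amounting to no step beyond the scatter. Compound 3 is estimated at 5500 nM, between 2000 nM and 15000 nM.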

Compound 3, half-maximal inhibitory concentration: 16200 nM
Beside the measured number, compound 3's estimate is 2.9-fold (0.47 log units) below it; measured number outside the range, above it.
By their numbers in this assay, from the lowest: compounds 2, 1 and 3 (each within the scatter of the next, the first and the last beyond it).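

At the place on a double-bonded chain carbon bound to a double-bonded ring carbon, the aryl group does affect the result: in this assay, 2,4-dichlorophenyl in place of 3-chlorophenyl gives a 2.7-fold higher number from compound 2 to compound 3 (0.43 log units; beyond the scatter) and the number does not stay within the scatter. This single pair cannot separate the second chlorine from the altered chlorine pattern. No evidence here explains the step. The compounds shown leave open how plain phenyl, 4-chlorophenyl or a ring carrying an amine would read at this place.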